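From compound 3 to compound 4: one added methoxy

The source may hold more compounds than are shown below. What is called first, only, known or untested is meant among the compounds shown, and "the series" means these compounds.

Compounds 1 to 3 share the core of compound 1 (`CCCCc1oc2ccccc2c1C(=O)c1ccc(OCC(=O)NC(C)C)cc1`) and differ in the group on the side-chain carbonyl. In a functional assay on MCF7 cells (Homo sapiens) for antiproliferative activity, read by MTT assay, with a stated time of 24 h (a higher number here means a weaker inhibitor, a lower number a stronger inhibitor), compound 1 reads > 50000 nM as a limit of the assay, not a number. Compound 2 (`CCCCc1oc2ccccc2c1C(=O)c1ccc(OCC(=O)N2CCCC2)cc1`) gives 42400 nM in the same assay. Compound 3 (`CCCCc1oc2ccccc2c1C(=O)c1ccc(OCC(=O)Nc2ccccc2)cc1`) gives 33600 nM and stands within the scatter of compound 2, so the two cannot be ordered. The steps linking the three are all small (an at least 1.1-fold lower number from compound 1 to compound 2 (0.07 log units; that floor lies within the scatter); an at least 1.4-fold lower number from compound 1 to compound 3 (0.17 log units; that floor lies within the scatter); a 1.3-fold lower number from compound 2 to compound 3 (0.10 log units; within the scatter)).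

Compound 4 (`CCCCc1oc2ccccc2c1C(=O)c1ccc(OCC(=O)Nc2cccc(OC)c2)cc1`) has methoxy in place of hydrogen on an aromatic carbon, meta to a large group, which turns phenyl to 3-methoxyphenyl (methoxy in place of hydrogen on an aromatic carbon). Going by the values given here, no measured step tests a substituent at this place. Among the compounds with values here, the nearest evidence is the exchange of groups on the carbonyl carbon, and the only such step between two true numbers stays within the scatter (a 1.3-fold lower number from compound 2 to compound 3 (0.10 log units; within the scatter)). The step expected in this assay is therefore none beyond the scatter, with no firm direction (a 1.1-fold lower number from compound 3 to compound 4 (0.05 log units; within the scatter)). For compound 4 the estimated value is 30000 nM (expected range 13000 nM to 60000 nM).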

Compound 4, half-maximal inhibitory concentration: 38500 nM
Compound 4: the middle estimate sits 1.3-fold (0.11 log units) below what was measured; the measured number falls inside the stated range.
By their numbers in this assay, from the lowest: compounds 3, 4 and 2 (each within the scatter of the next). At a limit, above all of these: compound 1.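

In this assay, going by these compounds alone, methoxy on an aromatic carbon, meta to a large group, gives the first reading for a substituent on this phenyl ring, and the change stays within the scatter: a 1.1-fold higher number from compound 3 to compound 4 (0.06 log units; within the scatter). The exchange of pyrrolidin-1-yl for (3-methoxyphenyl)amino on the carbonyl carbon also stays within the scatter (a 1.1-fold lower number from compound 2 to compound 4 (0.04 log units; within the scatter)), so compounds 2, 3 and 4 cannot be ordered and this one added methoxy shows no effect that can be told apart from repeat variation. Compound 1 reads > 50000 nM, which is a limit and not a number, so the step to the 3-methoxyphenyl amide reads only as an at least 1.2-fold lower number from compound 1 to compound 4 (0.11 log units; that floor lies within the scatter), and its true size stays unknown: the limit of > 50000 nM in this assay, at which 1 of the 4 values shown sits.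

Open, as far as these compounds go, is whether this phenyl ring responds to anything other than a single methoxy at this place, such as a carboxylic acid, an amine or a chlorine atom, since one substituent at one place gives no trend. Also open, from the compounds shown here alone, is whether changes away from the amide end, such as a longer chain in place of the butyl group on the shared core, would move the reading in this assay beyond the scatter.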